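The source may report more compounds than this note shows. Statements on the series, on what has been measured and on what is new or still open speak of the compounds shown alone.

The measured compounds:
compound 1, `COc1ccc(Cn2nncc2-c2cc(OC)c(OC)c(OC)c2)cc1O`, gives 1830 nM
compound 2, `COc1ccc(Cn2nncc2-c2cc(OC)c(OC)c(OC)c2)cc1[N+](=O)[O-]`, gives > 10000 nM
compound 3, `COc1ccc(-c2cnnn2Cc2cc(OC)c(OC)c(OC)c2)cc1O`, gives 530 nM

All three were tested in a functional assay on K562 cells (Homo sapiens) for cytotoxicity, read by MTT assay, with a stated time of 5 days; on this read-out higher numbers stand for weaker inhibition and lower numbers for stronger inhibition. Compound 3 gives the lowest number of the two that are plain numbers, and compound 1 stands nearest to it. The value of compound 2 is a limit of the assay, not a number, so only a bound is known for it; this is the case noted in the limit of > 10000 nM in this assay, at which 1 of the 3 values shown sits.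

Compound 1 and compound 2 differ in one place: nitro in place of hydroxy on an aromatic carbon. That change gave an at least 5.4-fold higher number from compound 1 to compound 2 (0.73 log units; beyond the scatter), a weakening of the cell-killing effect, the size of which is only bounded from one side because compound 2 sits at the limit.

Compound 1 and compound 3 are built from the same atoms joined differently; the difference between the two cores is not broken down here.

Compound 4, `COc1ccc(-c2cnnn2Cc2cc(OC)c(OC)c(OC)c2)cc1[N+](=O)[O-]`, has not yet been measured. It differs from compound 3 in one place: nitro in place of hydroxy on an aromatic carbon. The surroundings of the place are described in the same words as for the change from compound 1 to compound 2, so this is the same change made on the core of compound 3. From it a step of about a 6.6-fold higher number from compound 3 to compound 4 (0.82 log units; beyond the scatter) is expected in this assay, resting on the one measured case, where compound 2 gives > 10000 nM after the same change. Compound 4 is therefore estimated at 3500 nM, with a likely range from 1200 nM to 12000 nM.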

Compound 4, half-maximal inhibitory concentration: > 10000 nM
Compound 4: no number, only a limit; the forecaster's own chance of this, stated with the estimate: 35%; at least 2.8-fold (0.45 log units) between middle value and limit.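

In this assay, putting nitro in place of hydroxy on the core of compound 3 gave an at least 18-fold higher number from compound 3 to compound 4 (1.27 log units; beyond the scatter) and so repeated, in direction, the loss of cell-killing effect already seen on the core of compound 1. The change therefore carried over from one core to the other, in the sense that both hydroxy compounds give a measurable number and both nitro compounds do not, but neither step has a known full size and no claim can be made that one core suffers more than the other: the same change on two cores in this assay, an at least 5.4-fold higher number (0.73 log units; beyond the scatter) from compound 1 to compound 2 and an at least 18-fold higher number (1.27 log units; beyond the scatter) from compound 3 to compound 4; the limit leaves it open whether they differ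

Compound 4 gives > 10000 nM and this is a limit of the assay, not a number, so the two nitro compounds cannot be ranked against each other: the limit of > 10000 nM in this assay, at which 2 of the 4 values shown sit.

The compounds shown hold only hydroxy and nitro at this place, so they leave open whether the loss belongs to nitro alone or would also follow from another replacement, such as an amine, a fluorine atom or a carboxylic acid. They also leave open whether the same step would appear on any core other than these two, and how much weaker the two nitro compounds really are.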